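Compound 1 and its 1-methyl-1H-imidazol-2-yl counterpart

The source may hold more compounds than are shown below. What is called first, only, known or untested is meant among the compounds shown, and "the series" means these compounds.

Compound 1 `CCCC[S+]([O-])c1sc2nc(-c3ncco3)cc(-c3ccccc3)c2c1N`: 2.8 ug/mL
Compound 2 `CCCC[S+]([O-])c1sc2nc(-c3nccs3)cc(-c3ccc(CNC(=O)NCC)cc3)c2c1N`: 8.17 ug/mL

Of the compounds shown here, two have been measured so far in a physicochemical assay for solubility, read by LC-MS, with a stated time of 16 h, at pH 7; a lower number here means a less soluble compound, a higher number a more soluble compound. Compound 1 gives 2.8 ug/mL, the lower of the two numbers, while compound 2 reaches 8.17 ug/mL, a gap beyond the scatter. These two compounds differ in more than one place, so their gap cannot be read as the effect of any single change.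

The next compound to be tested is compound 3 `CCCC[S+]([O-])c1sc2nc(-c3nccn3C)cc(-c3ccccc3)c2c1N`, which keeps the core of compound 1 and alters one group. It carries 1-methyl-1H-imidazol-2-yl in place of 1,3-oxazol-2-yl on an aromatic carbon. Going by the values given here, no measured pair shows this exchange, so the expectation rests on the structural change alone and remains uncertain. A modest upward move in this assay is expected, and the estimated step is a 2.1-fold higher number from compound 1 to compound 3 (0.33 log units; beyond the scatter). For compound 3 the expected value is 6 ug/mL, with an estimated range from 2 ug/mL to 20 ug/mL.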

Compound 3, solubility: 1.9 ug/mL
Compound 3: middle estimate off by 3.2-fold (0.50 log units), on the high side; the measured number lies below the stated range.
By their numbers in this assay, from the lowest: compounds 3 and 1 (each within the scatter of the next); then compound 2.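

The exchange of 1,3-oxazol-2-yl for 1-methyl-1H-imidazol-2-yl, on an aromatic carbon next to the ring nitrogen, gives in this assay a step of a 1.5-fold lower number from compound 1 to compound 3 (0.17 log units; within the scatter), and this is the only step shown that isolates a single place. At this position, then, one five-membered aromatic ring with 2 hetero atoms has been swapped for another, with the same counts of hydrogen-bond donors and acceptors under both groups, and the read-out shows no difference that can be separated from the usual scatter; the core of compound 1 with its phenyl group holds compound 1 and compound 3 together at the low end of the numbers shown. No measurement at hand speaks to what lies behind this result.

From the compounds shown here alone, whether a carboxylic acid or an open-chain amine at this same place would move the number beyond the scatter stays open. Also open is which of the several differences carried by compound 2, including the ethyl urea side chain on its phenyl ring, accounts for its separate standing in this assay.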